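Notes on a cyclopentyl swap in compound 1

A few compounds are considered here, and "the series" means these few. Any claim that something is new, unique, unknown or untested is made for them only; others in the source may bear on it.

- compound 1 `O=C1NC(=O)/C(=C/C(c2ccc(-c3ccc4cccc(F)c4c3)[nH]c2=O)C2CCCCC2)O1`: 1.09 h
- compound 2 `CC(C)C(c1ccc(-c2ccc3cccc(F)c3c2)[nH]c1=O)C1C(=O)NC(=O)N1C`: 0.375 h

In an ADME assay on microsomes from liver (Homo sapiens) for metabolic stability (on this read-out higher numbers stand for a longer-lived compound and lower numbers for a shorter-lived compound), compound 1 holds the higher of the two numbers, and compound 2 lies lower by more than the usual scatter. Still unmeasured, compound 3 `O=C1NC(=O)/C(=C/C(c2ccc(-c3ccc4cccc(F)c4c3)[nH]c2=O)C2CCCC2)O1` differs from compound 1 in one place: cyclopentyl in place of cyclohexyl on a saturated chain carbon bound to an aromatic carbon and a double-bonded chain carbon. Among the compounds with values here, no measured pair shows this change, so no step beyond the scatter is expected in this assay, and no firm direction can be given. The expected step of a 1.1-fold higher number from compound 1 to compound 3 (0.04 log units; within the scatter) stays within the scatter. For compound 3 the estimated value is 1.2 h, with an expected range of 0.55 h to 2.5 h.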

Compound 3, half-life: 1.21 h
The estimate for compound 3 lay 1.0-fold (0.00 log units) below the measured number; the measured number falls inside the stated range.
By their numbers in this assay, from the lowest: compound 2; then compounds 1 and 3 (each within the scatter of the next).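

In this assay, cyclopentyl in place of cyclohexyl on the saturated chain carbon gives a 1.1-fold higher number from compound 1 to compound 3 (0.05 log units; within the scatter). Within the data shown here, this is the first pair that differs in one place, and it shows that these two rings of carbon only are not told apart at this position by this read-out. No measurement at hand bears on this result.

On these data alone, what an amine or a longer chain at this position would give in this assay stays open. Compound 2 differs from compound 1 in more than one place, so its lower number cannot be tied to any one group.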